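The source may report more compounds than this note shows. Statements on the series, on what has been measured and on what is new or still open speak of the compounds shown alone.

Measured compounds:
compound 1, `COC(=O)C1=C(C)N=C(C)/C(=C(\O)OC)C1c1ccccc1C(F)(F)F`, 1.51 nM
compound 2, `CCOc1ccccc1C1C(C(=O)OC)=C(C)N=C(C)/C1=C(\O)OC`, 110 nM
compound 3, `COC(=O)C1=C(C)N=C(C)/C(=C(\O)OC)C1c1ccccc1F`, 42.7 nM

These three compounds share one core and differ only in the substituent on the aromatic ring. In a functional assay (muscle tissue) with Cavia porcellus as the target (a lower number here means that less compound is needed, a higher number that more compound is needed for the effect), compound 3 gives 42.7 nM, which is the second highest of the three numbers: it stands closest to compound 2, as a 2.6-fold lower number from compound 2 to compound 3 (0.41 log units; beyond the scatter) shows, and furthest from compound 1, with a 28-fold higher number from compound 1 to compound 3 (1.45 log units; beyond the scatter).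

Compound 4, `COC(=O)C1=C(C)N=C(C)/C(=C(\O)OC)C1c1ccc(Cl)cc1Cl`, has not yet been measured. It differs from compound 3 in one place: 2,4-dichlorophenyl in place of 2-fluorophenyl on a saturated ring carbon.

Within the data shown here, no measured step replaces fluoro with 2,4-dichlorophenyl, so the expectation rests on what is known about the aromatic substituent. The step of a 28-fold higher number from compound 1 to compound 3 (1.45 log units; beyond the scatter) shows that going from trifluoromethyl to fluoro on the aromatic carbon raised the number by a large amount, while a 2.6-fold lower number from compound 2 to compound 3 (0.41 log units; beyond the scatter) shows that fluoro in place of ethoxy lowered it modestly. Halogen substitution heavier than fluoro therefore appears, on this small set, to be associated with lower numbers.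

Compound 4 is accordingly expected to give a lower number in this assay, with an estimated step of an 8.5-fold lower number from compound 3 to compound 4 (0.93 log units; beyond the scatter). The estimate for compound 4 is 5 nM, expected between 1.2 nM and 25 nM.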

Compound 4, half-maximal effective concentration: 640 nM
For compound 4 the middle estimate is 130-fold (2.11 log units) below the measured one; measured number above the stated range.
By their numbers in this assay, from the lowest: compound 1; then compound 3; then compound 2; then compound 4.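

In this assay, replacing 2-fluorophenyl with 2,4-dichlorophenyl on the saturated ring carbon gives a 15-fold higher number from compound 3 to compound 4 (1.18 log units; beyond the scatter), which makes this the first change shown that moves the number strongly upward from the fluoro compound. Compounds 1, 2 and 3 each carry one substituent on the aromatic ring, whereas compound 4 carries two chlorine atoms and has the highest number of the four, so halogen content does not track with a low number here: the trifluoromethyl of compound 1 sits at the low end, the two chlorines of compound 4 at the high end, and the fluoro of compound 3 in between, with the ethoxy of compound 2, which has no halogen, falling below compound 4. Nothing measured in this set accounts for the rise.

Because this step removes fluorine and adds two chlorines at once, the compounds shown cannot separate what the change of halogen contributes from what the second substituent contributes. As far as these compounds go, how a phenyl ring bearing a single chlorine, an unsubstituted phenyl ring or a phenyl ring bearing a nitro group would stand in this assay remains open.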